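Swapping a piperazine for a pyridinyloxy on a nitrile-bearing ring

The source may report more compounds than this note shows. Statements on the series, on what has been measured and on what is new or still open speak of the compounds shown alone.

Measured compounds:
- compound 1, `N#Cc1ccc(-n2ccc3ccncc32)cc1`: 94%
- compound 2, `CN1CCN(c2cc(Oc3cccnc3)ccc2C#N)CC1`: 8%
- compound 3, `N#Cc1ccc(Oc2cccnc2)c(F)c1`: 52%

In an assay on isolated protein for inhibition of Aromatase (Homo sapiens), read by fluorescence, tested at 1 uM (on this read-out lower numbers stand for less inhibition and higher numbers for more inhibition at the one concentration tested (going by the name of the read-out)), compound 1 gives 94%. Compound 3 gives 52% in this assay. Compound 2 gives 8%, the lowest of the three numbers; its gap to compound 3 and its wider gap to compound 1 both lie beyond the scatter of repeated measurements.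

The unmeasured compound 4, `N#Cc1ccc(Oc2cccnc2)cc1Oc1cccnc1`, shares with compound 2 the ring carrying a cyano group and a (pyridin-3-yl)oxy group, and differs in one place: (pyridin-3-yl)oxy in place of 4-methylpiperazin-1-yl on an aromatic carbon. Going by the values given here, no pair of measured compounds differs in only one place, so no measured step can be read off directly. Still, compound 3, which also carries a (pyridin-3-yl)oxy group on a ring bearing a cyano group and no 4-methylpiperazin-1-yl group, gives 52%, which is well above compound 2.

For compound 4 the step is therefore expected to be upward and beyond the scatter, with an expected change of a number 47 percentage points higher from compound 2 to compound 4 (beyond the scatter) in this assay. Compound 4 is estimated to give 55%, within a range of 30% to 80%.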

Compound 4, a percentage reported as inhibition, at one concentration (the size of the read-out at that concentration, not a potency): 81%
Beside the measured number, compound 4's estimate is 26 percentage points below it, and the stated range ends below it.
By their numbers in this assay, from the lowest: compound 2; then compound 3; then compound 4; then compound 1.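

In this assay, going by these compounds alone, the replacement on the aromatic carbon ortho to a cyano group gives a number 73 percentage points higher from compound 2 to compound 4 (beyond the scatter), the first direct one-place comparison in this set and a sign that the outcome is highly sensitive to the group at this position. The size of this step is notable, as 4-methylpiperazin-1-yl and (pyridin-3-yl)oxy have equal counts of heavy atoms, hydrogen-bond donors and hydrogen-bond acceptors, and neither carries a net charge, so those counts do not separate the two groups. They do differ in the ring, which is six-membered and non-aromatic with two hetero atoms in one case and six-membered and aromatic with one hetero atom in the other, and no measurement shown bears on why this change has such a large effect.

This single swap changes the ring type and the atoms of the group together, so the compounds shown cannot assign the step to either feature alone. Going by these compounds, whether an open-chain amine such as dimethylamino or a small ether such as methoxy on this carbon would give a number closer to that of compound 2 or compound 4 also remains open.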